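The source may hold more compounds than are shown below. What is called first, only, known or untested is meant among the compounds shown, and "the series" means these compounds.

Compound 1 `CS(=O)(=O)CCCOc1ccc2c(c1)OC(COc1ccc(CCC(=O)O)c(F)c1)CC2`: 36300 nM in a functional assay on HEK293 cells for agonist activity at Free fatty acid receptor 1 (Homo sapiens), read by fluorescence and calcium flux, with a stated time of 10 min; on this read-out lower numbers stand for an effect already at smaller amounts and higher numbers for an effect only at larger amounts of compound.
Compound 2 `COCCOc1ccc2c(c1)OC(COc1ccc(CCC(=O)O)c(F)c1)CC2`: 2370 nM in this assay.
Compound 3 `COc1ccc2c(c1)OC(COc1ccc(CCC(=O)O)c(F)c1)CO2`: 1470 nM in this assay.

Compound 3 holds the lowest number of the three in this assay; its gap to compound 2 lies within the scatter, so no order between these two is claimed, whereas its gap to compound 1 lies well beyond it. Among the compounds with values here, the only measured step, a 15-fold lower number from compound 1 to compound 2 (1.19 log units; beyond the scatter), concerns the chain substituent and not the aromatic one, so it does not bear directly on the change to compound 4 `O=C(O)CCc1ccc(OCC2COc3ccc(Br)cc3O2)cc1F`, which is bromo in place of methoxy on an aromatic carbon. Within the data shown here, no measured pair covers this swap. The expectation for compound 4 in this assay is accordingly a step of a 1.0-fold higher number from compound 3 to compound 4 (0.01 log units; within the scatter), not beyond the scatter. Compound 4 is estimated at 1500 nM, in the range 500 nM to 5000 nM.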

Compound 4, half-maximal effective concentration: 2240 nM
Compound 4: middle estimate off by 1.5-fold (0.17 log units), on the low side; the measured number falls inside the stated range.
By their numbers in this assay, from the lowest: compounds 3, 4 and 2 (each within the scatter of the next); then compound 1.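

Bromo in place of methoxy on this aromatic carbon gives a 1.5-fold higher number from compound 3 to compound 4 (0.18 log units; within the scatter) in this assay and is the first measured swap at this position, since the earlier step concerned the chain. Here, one heavy atom replaces two and the hydrogen-bond acceptor of the methoxy is absent, with no change that can be told from the scatter. No measurement on hand accounts for this step.

From the compounds shown here alone, whether an amine or a nitrile on this aromatic carbon would stay within the scatter remains open. So does whether bromo would behave the same way on the core of compound 2.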